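The source may hold more compounds than are shown below. What is called first, only, known or untested is meant among the compounds shown, and "the series" means these compounds.

Of the compounds shown here, three built on one shared core have been measured in a physicochemical assay for lipophilicity, read by HPLC, in phosphate buffer, measured as chromatographic lipophilicity, at pH 7.4; a lower number here means a more polar compound, a higher number a more lipophilic compound. Compound 1 `COc1ccc2nc(C)cc(OCCNc3cc(C)cc(C)c3)c2c1` gives 6.93 in this assay, and compound 3 `COc1ccc2nc(C)cc(OCC(=O)Nc3ccc(Cl)c(C(F)(F)F)c3)c2c1` gives 6.22. Compound 2 `COc1ccc(NC(=O)COc2cc(C)nc3ccc(OC)cc23)cc1` gives 4.22 in this assay, the lowest of the three numbers; its gap to compound 3, and its larger gap to compound 1, both lie beyond the usual scatter of such measurements. The piece follows the step from compound 2 to compound 4 `COc1ccc2nc(C)cc(OCC(=O)Nc3cc(C)nc(C)n3)c2c1`, which has not yet been measured in this assay. The two structures differ in one place: 2,6-dimethylpyrimidin-4-yl in place of 4-methoxyphenyl on an amide-type nitrogen. The group that leaves carries one hydrogen-bond acceptor and a ring of carbon only, while the group that enters carries two hydrogen-bond acceptors in a ring with 2 hetero atoms. Within the data shown here, no two measured compounds differ in a single place, so no measured step of this kind exists to lean on. The step in this assay is expected to be a fall of moderate size, a number 0.72 log units lower from compound 2 to compound 4 (beyond the scatter), beyond the scatter. Because compound 2 gives 4.22, the new compound should land somewhat lower. Compound 4 is estimated at 3.5, with a range from 2.8 to 4.2.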

Compound 4, distribution coefficient: 3.24
Compound 4: middle estimate off by 0.26 log units, on the high side; low and high end bracket the measured number.
By their numbers in this assay, from the lowest: compound 4; then compound 2; then compound 3; then compound 1.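

Among these compounds, until now no two compounds could be compared directly in this assay, and replacing 4-methoxyphenyl with 2,6-dimethylpyrimidin-4-yl on the amide-type nitrogen supplies the first such comparison: a number 0.98 log units lower from compound 2 to compound 4 (beyond the scatter) in this single exchange. The two groups have the same number of heavy atoms, no hydrogen-bond donors and no net charge, yet a ring of carbon only gives way to one with 2 hetero atoms, so this position responds to what the ring is made of even when the counted size stays equal. Nothing measured here speaks to why the number moves.

This one step bundles several changes, with the methoxy group leaving and the ring nitrogens and methyl groups entering together, and it cannot separate their shares. From the compounds shown here alone, a pyridin-3-yl group, or a pyrimidine ring without its methyl groups, on the same amide-type nitrogen could show how much of the step belongs to each part, and whether the same exchange moves the number by a similar amount on other compounds with this core remains open too.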